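This account rests on a few compounds, and the source may have more. Where it says the series, first, only, none or still open, it means among the compounds named here.

Measured compounds:
- compound 1 `Cc1ccc(C)c(C(=O)NC(CCN(C)C)c2ccc(Cl)cc2)c1` gives 2880 nM in an assay on NIH3T3 cells with Urotensin-2 receptor (Homo sapiens) as the target; on this read-out lower numbers stand for an effect already at smaller amounts and higher numbers for an effect only at larger amounts of compound
- compound 2 `CN(C)CCC(NC(=O)c1ccccc1)c1ccc(Cl)cc1` gives 1410 nM in this assay

On these two numbers compound 2 stands lowest, with compound 1 next at a 2.0-fold lower number from compound 1 to compound 2 (0.31 log units; beyond the scatter); that single step, which swapped the group on the carbonyl carbon, is the only one measured at this site.

Compound 3 `Cc1ccccc1NC(=O)NC(CCN(C)C)c1ccc(Cl)cc1` changes the same carbonyl carbon again: (2-methylphenyl)amino in place of phenyl on a carbonyl carbon. The carbonyl carbon, whose other neighbour is an amide-type nitrogen, now also carries this nitrogen-linked group. Going by the values given here, the one relevant step was modest, and it removed two methyl groups rather than adding an amino-linked ring, so it gives only weak guidance. The expected step in this assay is therefore a 1.3-fold higher number from compound 2 to compound 3 (0.11 log units; within the scatter), not clearly beyond the scatter in either direction. Compound 3 is estimated at 1800 nM, with a range from 500 nM to 6500 nM.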

Compound 3, half-maximal effective concentration: 2290 nM
For compound 3 the middle estimate is 1.3-fold (0.10 log units) below the measured one; measured number inside the range.
By their numbers in this assay, from the lowest: compounds 2, 3 and 1 (each within the scatter of the next, the first and the last beyond it).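

In this assay, the (2-methylphenyl)amino group on the carbonyl carbon gives a 1.6-fold higher number from compound 2 to compound 3 (0.21 log units; within the scatter) and a 1.3-fold lower number from compound 1 to compound 3 (0.10 log units; within the scatter), and both steps lie within the scatter. Going by these compounds alone, this is the first group at this position that links its ring through a nitrogen and brings a hydrogen-bond donor, and that new link leaves compound 3 without a clear difference from either amide, even though compound 1 and compound 2 are separated beyond the scatter. No supporting measurement is available to explain these numbers.

From the compounds shown here alone, the nitrogen link and the methyl group enter together in one step, so their separate contributions remain open. Also open, going by these compounds, is what a plain phenylamino group, a saturated cyclohexyl ring or a carboxylic acid on this carbonyl carbon would give.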